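Swapping a methoxy for methylsulfanyl on compound 2

The source may hold more compounds than are shown below. What is called first, only, known or untested is meant among the compounds shown, and "the series" means these compounds.

compound 1 `COc1ccc(-c2nc3cc[nH]cc-3n2)cc1` gives 1.7 mg/kg
compound 2 `COc1ccc(-c2nc3cc[nH]cc-3n2)c(OC)c1` gives 0.3 mg/kg
compound 3 `COc1ccc(-c2nc3cc[nH]cc-3n2)cc1OC` gives 0.4 mg/kg

In a functional assay on the whole organism with Canis familiaris (Canis lupus familiaris) as the target (on this read-out higher numbers stand for an effect only at larger amounts of compound and lower numbers for an effect already at smaller amounts), compound 2 at 0.3 mg/kg and compound 3 at 0.4 mg/kg sit within the usual scatter of each other, and both numbers lie clearly under that of compound 1. Compound 4 `COc1cc(SC)ccc1-c1nc2cc[nH]cc-2n1`, not yet measured, differs from compound 2 by methylsulfanyl in place of methoxy on an aromatic carbon. Within the data shown here, two measured steps bear on it only loosely: a 5.7-fold lower number from compound 1 to compound 2 (0.75 log units; beyond the scatter) and a 4.3-fold lower number from compound 1 to compound 3 (0.63 log units; beyond the scatter) each add a methoxy in place of hydrogen. Among the measured compounds shown here, compound 4 keeps the methoxy gained in the first of these, and no measured step swaps methoxy for methylsulfanyl. A step within the scatter is therefore expected, with no firm direction. The estimated change is a 1.3-fold higher number from compound 2 to compound 4 (0.12 log units; within the scatter) and is expected to stay small. Compound 4 is expected at 0.4 mg/kg within a range from 0.15 mg/kg to 1.1 mg/kg by this estimate.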

Compound 4, dose for half-maximal effect: 0.2 mg/kg
For compound 4 the middle estimate is 2.0-fold (0.30 log units) above the measured one, and the stated range covers the measured number.
By their numbers in this assay, from the lowest: compounds 4, 2 and 3 (each within the scatter of the next); then compound 1.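

In this assay, the swap gives a 1.5-fold lower number from compound 2 to compound 4 (0.18 log units; within the scatter) and so stays within the usual scatter. The earlier compounds shown here showed only what adding a methoxy in place of hydrogen does, whereas this result shows that a second group, methylsulfanyl, can take the place of methoxy at this position without a change that stands out from the scatter. Nothing measured here points to a cause for this result.

Still open, going by these compounds, is how an amine, a carboxylic acid or a longer chain would fare at this position. These compounds also leave open whether methylsulfanyl would behave the same way in place of the other methoxy of compound 2.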